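Swapping a Cyclic Sulfonamide for an Aminothiazole

A few compounds are considered here, and "the series" means these few. Any claim that something is new, unique, unknown or untested is made for them only; others in the source may bear on it.

compound 1 `CC(C)C(c1ccc(-c2ccc3cccc(F)c3c2)[nH]c1=O)N1CCCCS1(=O)=O`: 14 nM
compound 2 `CCn1ncc2c(F)cc(-c3ccc(C(CC)(CC)c4nnc[nH]4)c(=O)[nH]3)cc21`: 17 nM
compound 3 `CCn1ncc2c(C)cc(-c3ccc([C@@]4(C)CCNC4=O)c(=O)[nH]3)cc21`: 5 nM

In an assay on CHO cells for displacement of a labelled ligand from prostaglandin E2 receptor EP3 subtype (Homo sapiens), read by radioligand binding (a higher number here means a weaker inhibitor, a lower number a stronger inhibitor), compound 1 gives 14 nM, the second highest of the three numbers. Compound 2 gives 17 nM, which sits within the scatter of compound 1. Compound 3 gives 5 nM, a lower number beyond the scatter. Among the measured compounds shown here, no two measured compounds differ in a single place, so no step has been measured. Compound 4 `CC(C)C(c1cnc(N)s1)c1ccc(-c2ccc3cccc(F)c3c2)[nH]c1=O` differs from compound 1 by a group of 6 heavy atoms (3 carbon, 2 nitrogen, 1 sulfur; one five-membered aromatic ring with 2 hetero atoms) in place of a group of 8 heavy atoms (4 carbon, 1 nitrogen, 2 oxygen, 1 sulfur; one six-membered non-aromatic ring with 2 hetero atoms), on a saturated chain carbon bound to an aromatic carbon and a saturated chain carbon. A number close to that of compound 1 is expected for compound 4, because compound 2 gives 17 nM while bearing a five-membered aromatic ring with 2 hetero atoms on a saturated chain carbon. The estimate for compound 4 is 20 nM, ranging from 6 nM to 65 nM. The expected step of a 1.4-fold higher number from compound 1 to compound 4 (0.15 log units; within the scatter) is small, within the scatter.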

Compound 4, inhibition constant: 16 nM
For compound 4 the middle estimate is 1.3-fold (0.10 log units) above the measured one; measured number inside the range.
By their numbers in this assay, from the lowest: compound 3; then compounds 1, 4 and 2 (each within the scatter of the next).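

In this assay, exchanging the six-membered non-aromatic ring for 2-amino-1,3-thiazol-5-yl on this saturated chain carbon gives a 1.1-fold higher number from compound 1 to compound 4 (0.06 log units; within the scatter). This first measured step at the position shows that the two groups read alike on this core, despite their different rings and the hydrogen-bond donor that enters with the aminothiazole. Nothing available accounts for this match.

The compounds shown leave open what the amine on the thiazole contributes, which a plain 1,3-thiazol-5-yl group would test. They also leave open how an open-chain sulfonamide would read on this carbon.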